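Swapping the thiophene on a tropane-like transporter ligand

The source may hold more compounds than are shown below. What is called first, only, known or untested is meant among the compounds shown, and "the series" means these compounds.

Two compounds share one core and differ only in the aromatic group attached to the phenyl ring. Compound 1 `COC(=O)C1C2CCC3CCC1N(C/C2=C\c1ccc(-c2ccc(N(C)C)cc2)cc1)C3` carries a 4-(dimethylamino)phenyl group and gives 57.9 nM in an assay with Norepinephrine transporter (Rattus norvegicus) as the target; on this read-out higher numbers stand for weaker inhibition and lower numbers for stronger inhibition. Within the data shown here, compound 2 `COC(=O)C1C2CCC3CCC1N(C/C2=C\c1ccc(-c2ccc(C)s2)cc1)C3` carries a 5-methylthiophen-2-yl group instead and gives 22.5 nM in this assay, the lowest of the two numbers so far; the step of a 2.6-fold lower number from compound 1 to compound 2 (0.41 log units; beyond the scatter) shows that this exchange made a modest difference. Compound 3 `COC(=O)C1C2CCC3CCC1N(C/C2=C\c1ccc(-c2ccsc2)cc1)C3` is not yet measured. It differs from compound 2 in one place: thiophen-3-yl in place of 5-methylthiophen-2-yl on an aromatic carbon. Among the measured compounds shown here, no measured step covers exactly this change; the only step in hand, a 2.6-fold lower number from compound 1 to compound 2 (0.41 log units; beyond the scatter), replaced one whole aromatic group with another of a different kind, whereas here one thiophene replaces another. For compound 3 the expected value in this assay is therefore close to that of compound 2, the estimated step being a 1.3-fold higher number from compound 2 to compound 3 (0.12 log units; within the scatter), with a middle estimate of 30 nM and a likely range from 12 nM to 80 nM.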

Compound 3, inhibition constant: 20.5 nM
Beside the measured number, compound 3's estimate is 1.5-fold (0.17 log units) above it; measured number inside the range.
By their numbers in this assay, from the lowest: compounds 3 and 2 (each within the scatter of the next); then compound 1.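

Changing the thiophene at this position alters both where the ring is attached and whether it carries a methyl, yet in this assay the result is only a 1.1-fold lower number from compound 2 to compound 3 (0.04 log units; within the scatter). Compound 3 also stands apart from the group with the dimethylamino substituent, with a 2.8-fold lower number from compound 1 to compound 3 (0.45 log units; beyond the scatter), so two different thiophenes, not just one, now give lower numbers than 4-(dimethylamino)phenyl at this position. Nothing available on these compounds explains why the numbers fall as they do.

On these data alone, the methyl group and the point of attachment changed together, so what each does alone remains open. As far as these compounds go, it also remains open how a furan, a pyridine, an unsubstituted phenyl or a saturated amine such as piperidine would compare with the thiophenes in this place.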